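Replacing an Acetyl Group with Carboxymethyl

A few compounds are considered here, and "the series" means these few. Any claim that something is new, unique, unknown or untested is made for them only; others in the source may bear on it.

Measured compounds:
compound 1, `CC1CCC(/C=N/c2ccc(C(F)(F)F)cc2)=C2NC=C(C(=O)O)C(=O)N21`: > 100 umol/kg
compound 2, `CC(=O)c1ccc(/N=C/C2=C3NC=C(C(=O)O)C(=O)N3C(C)CC2)cc1`: 0.75 umol/kg

Of the compounds shown here, two have been tested in a functional assay on the whole organism with Rattus norvegicus as the target; a lower number here means that less compound is needed, a higher number that more compound is needed for the effect. For compound 1 the result is a limit of the assay, not a number, and it is the value the limit of > 100 umol/kg in this assay, at which 1 of the 2 values shown sits, reached here. Among the measured compounds shown here, compound 2 is the only compound with an actual number, so it stands alone at the measurable end of the set. For the measured compounds named here, the one step that can be followed, an at least 130-fold lower number from compound 1 to compound 2 (2.12 log units; beyond the scatter), is a large one.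

Compound 3, `CC1CCC(/C=N/c2ccc(CC(=O)O)cc2)=C2NC=C(C(=O)O)C(=O)N21`, is not yet measured. It differs from compound 2 in one place: carboxymethyl in place of acetyl on an aromatic carbon. Going by the values given here, no measured step involves a carboxymethyl group, so the step from acetyl to trifluoromethyl is the only guide, and it shows that the group in this position can move the result strongly. Since the change now goes to a group unlike either of the two measured ones, a step beyond the scatter is expected, most likely toward a higher number. Compound 3 is therefore expected to give 10 umol/kg, within 1.5 umol/kg to 100 umol/kg, which means an estimated step of a 13-fold higher number from compound 2 to compound 3 (1.12 log units; beyond the scatter).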

Compound 3, dose for 50% inhibition: 5.8 umol/kg
The estimate for compound 3 lay 1.7-fold (0.24 log units) above the measured number, within the range that was stated.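

In this assay, the change from acetyl to carboxymethyl on this aromatic carbon, para to a large group, gives a 7.7-fold higher number from compound 2 to compound 3 (0.89 log units; beyond the scatter). Acetyl is therefore not the only group here that gives a measurable number, even though carboxymethyl, which brings in a hydrogen-bond donor that acetyl does not have, needs more compound for the effect. The step that replaces trifluoromethyl with carboxymethyl is an at least 17-fold lower number from compound 1 to compound 3 (1.23 log units; beyond the scatter), so this position now shows a clear spread across three different groups, with both acetyl and carboxymethyl well separated from trifluoromethyl. Compound 1 sits at a limit of the assay and not at a number, which means that the real size of both steps from it stays unknown: the limit of > 100 umol/kg in this assay, at which 1 of the 3 values shown sits.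

What the compounds shown leave open is which feature of carboxymethyl sets its result apart from that of acetyl, since the two groups differ in more than one respect. An ester or an amide in place of the free acid, or a longer chain ending in the same acid, would help to separate these features, and an amine at this position would test a quite different kind of group.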